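The compounds below may be only part of what the source reports. "The series", "measured", "known", "first", "only" and "open" are said of these compounds alone.

Measured in a functional assay on A549 cells (Homo sapiens) for antiproliferative activity, read by MTT assay, with a stated time of 72 h; a lower number here means a stronger inhibitor, a higher number a weaker inhibitor:
Compound 1 `C#Cc1cccc(Nc2ncnc3cc(OC)c(OCCCCC(=O)Nc4ccc(S(N)(=O)=O)cc4)cc23)c1`: 7720 nM
Compound 2 `COc1cc2ncnc(Nc3cccc(Cl)c3)c2cc1OCCCCC(=O)Nc1ccc(S(N)(=O)=O)cc1`: 11200 nM
Compound 3 `COc1cc2ncnc(Nc3ccc(F)cc3)c2cc1OCCCCC(=O)Nc1ccc(S(N)(=O)=O)cc1`: > 40000 nM, a limit and not a number

Compound 3 gives no number, only (the limit of > 40000 nM in this assay, at which 1 of the 3 values shown sits). Compound 4 `COc1cc2ncnc(Nc3ccc(OC(F)(F)F)cc3)c2cc1OCCCCC(=O)Nc1ccc(S(N)(=O)=O)cc1` carries trifluoromethoxy in place of fluoro on an aromatic carbon. Among the compounds with values here, no measured step covers this exchange. The nearest ones replace the whole aryl group, an at least 5.1-fold higher number from compound 1 to compound 3 (0.71 log units; beyond the scatter) and an at least 3.5-fold higher number from compound 2 to compound 3 (0.55 log units; beyond the scatter), while a 1.5-fold higher number from compound 1 to compound 2 (0.16 log units; within the scatter) stays within the scatter. Within the data shown here, those steps are the only guide, so a modest move towards a lower number is expected, though compound 4 may also return only a limit. The expected step is an at least 2.0-fold lower number from compound 3 to compound 4 (0.30 log units; that floor lies within the scatter). For compound 4 the estimate is 20000 nM, with an expected range of 8000 nM to 40000 nM.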

Compound 4, half-maximal inhibitory concentration: > 40000 nM
Compound 4 gave a limit, no number (the forecaster's own chance of this, stated with the estimate: 40%); middle value at least 2.0-fold (0.30 log units) away from the limit.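

In this assay, compound 4 also stands at a limit and not a number, > 40000 nM. The exchange of fluoro for trifluoromethoxy cannot be read, because both compounds give only a limit: the limit of > 40000 nM in this assay, at which 2 of the 4 values shown sit. With 4-(trifluoromethoxy)phenyl as a second such group on the nitrogen, replacing 3-chlorophenyl gives an at least 3.5-fold higher number from compound 2 to compound 4 (0.55 log units; beyond the scatter), and replacing 3-ethynylphenyl gives an at least 5.1-fold higher number from compound 1 to compound 4 (0.71 log units; beyond the scatter). The compounds shown leave open whether a methoxy group or an amine on this aromatic carbon would give a number rather than a limit.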